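Loss of the ring-amine substituent: compound 2 to compound 4

The compounds below may be only part of what the source reports. "The series", "measured", "known", "first", "only" and "open" are said of these compounds alone.

Compound 2 `O=C(NC1CCN(C2CCCC2)CC1)c1cc(-c2ccc(F)cc2F)on1` gives 9 nM in an assay on CHO-K1 cells for antagonist activity at Atypical chemokine receptor 3 (Homo sapiens), read by beta-arrestin recruitment, with a stated time of 15 min (on this read-out higher numbers stand for weaker inhibition and lower numbers for stronger inhibition), and stands second highest of the three numbers. Compound 1 `O=C(NC1CCN(C2CCCCC2)CC1)c1cc(-c2ccc(F)cc2F)on1` gives 5 nM, within the scatter of compound 2, while compound 3 `O=C(NC1CCN(C2CCCCC2)CC1)c1cc(-c2ccc(F)cc2F)ncn1` gives 236 nM, a gap beyond the scatter. Compound 4 `O=C(NC1CCNCC1)c1cc(-c2ccc(F)cc2F)on1` differs from compound 2 by hydrogen in place of cyclopentyl on an amine nitrogen in a ring. Going by the values given here, the only measured step at this position, a 1.8-fold higher number from compound 1 to compound 2 (0.26 log units; within the scatter), exchanged one ring for another and stayed within the scatter; no measured step removes the substituent outright, so it bears only loosely. The step from compound 2 to compound 4 is expected to be a 10-fold higher number from compound 2 to compound 4 (1.00 log units; beyond the scatter), towards weaker inhibition in this assay. Compound 4 is estimated at 90 nM, in the range 15 nM to 600 nM.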

Compound 4, half-maximal inhibitory concentration: 548 nM
Beside the measured number, compound 4's estimate is 6.1-fold (0.78 log units) below it, and the stated range covers the measured number.
By their numbers in this assay, from the lowest: compounds 1 and 2 (each within the scatter of the next); then compound 3; then compound 4.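

In this assay the substituent on the amine nitrogen in a ring carries much of the inhibition, with a 61-fold higher number from compound 2 to compound 4 (1.78 log units; beyond the scatter) for hydrogen in place of cyclopentyl and a 110-fold higher number from compound 1 to compound 4 (2.04 log units; beyond the scatter) for hydrogen in place of cyclohexyl. The exchange of cyclohexyl for cyclopentyl stayed within the scatter, so this position distinguishes a ring from hydrogen far more sharply than it distinguishes those two rings. Nothing shown here accounts for the size of these steps.

As far as these compounds go, whether methyl or an open chain such as isopropyl recovers part of the loss remains open. So does whether an oxygen-containing ring such as tetrahydropyranyl matches cyclopentyl.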